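The source may hold more compounds than are shown below. What is called first, only, known or untested is meant among the compounds shown, and "the series" means these compounds.

Working notes on the series. The compounds in hand share one core, a saturated chain ending in a small acyclic group. For the measured compounds named here, compound 2 `C/N=C(/NC#N)NCCCCCn1nc(-c2ccccc2)ccc1=O` gives 100 mg/kg in a functional assay on the whole organism (stomach) with Rattus norvegicus as the target (on this read-out lower numbers stand for an effect already at smaller amounts and higher numbers for an effect only at larger amounts of compound), the highest of the three numbers so far. Compound 1 `CN(C)/C(=N/CCCCn1nc(-c2ccccc2)ccc1=O)NC#N` gives 30.3 mg/kg and compound 3 `CC/N=C(\S)NCCCCn1nc(-c2ccccc2)ccc1=O` gives 37.2 mg/kg in this assay. The steps of a 3.3-fold higher number from compound 1 to compound 2 (0.52 log units; beyond the scatter) and a 2.7-fold lower number from compound 2 to compound 3 (0.43 log units; beyond the scatter) are both beyond the scatter, whereas a 1.2-fold higher number from compound 1 to compound 3 (0.09 log units; within the scatter) is not.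

Compound 4 `CN(C)/C(=N/CCCCCCn1nc(-c2ccccc2)ccc1=O)NC#N` is not yet measured. It differs from compound 2 as follows: a group of 9 heavy atoms (5 carbon, 4 nitrogen; no ring) in place of a group of 7 heavy atoms (3 carbon, 4 nitrogen; no ring), on a saturated chain carbon, five bonds along the chain from an aromatic nitrogen. Going by the values given here, the group that enters is the one carried by compound 1, now one chain carbon further out. Among the compounds with values here, the one step that bears on this is a 3.3-fold higher number from compound 1 to compound 2 (0.52 log units; beyond the scatter), which joined a change of the terminal group to a lengthening of the chain; the step to compound 4 reverses the group change while lengthening the chain again, and no pair in hand isolates chain length on its own. A modest lower number is therefore expected, a 2.2-fold lower number from compound 2 to compound 4 (0.35 log units; beyond the scatter), with wide uncertainty. For compound 4 the estimate in this assay is 45 mg/kg, ranging from 18 mg/kg to 110 mg/kg.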

Compound 4, dose for half-maximal effect: 93.1 mg/kg
Estimate against measurement, compound 4: 2.1-fold (0.32 log units) below, and the stated range covers the measured number.
By their numbers in this assay, from the lowest: compounds 1 and 3 (each within the scatter of the next); then compounds 4 and 2 (each within the scatter of the next).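

In this assay, placing the group of 9 heavy atoms in that of the group of 7 heavy atoms, on a saturated chain carbon, five bonds along the chain from an aromatic nitrogen, gives a 1.1-fold lower number from compound 2 to compound 4 (0.03 log units; within the scatter), so the two groups are not told apart on these chains. For the compounds shown here, compound 1 and compound 4 carry the same terminal group and differ only in chain length, the first such pair in hand, with compound 1 at 30.3 mg/kg and compound 4 at 93.1 mg/kg; the printed values thus point to chain length, rather than the terminal group alone, as a place where the series can move. No measurement in hand gives a reason for this result.

As far as these compounds go, whether a chain shorter than that of compound 1 or longer than that of compound 4 continues this picture remains open. Also open, from the compounds shown here alone, is how the sulfur-bearing group of compound 3, or a simple amine or carboxylic acid at the chain end, would read on the longer chains.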